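The source may report more compounds than this note shows. Statements on the series, on what has been measured and on what is new or still open speak of the compounds shown alone.

Compound 1, `Nc1cc(N)c2nc(-c3ccccc3)c(Sc3ccc(F)cc3)nc2c1`, was tested in a functional assay on SF-295 cells (Homo sapiens) for inhibition, read by sulforhodamine B assay, with a stated time of 48 h (on this read-out higher numbers stand for lower toxicity in this test and lower numbers for higher toxicity in this test), where compound 1 gives 64600 nM. Two further compounds share its core. Compound 2, `COc1cc(CNc2nc3cc(N)cc(N)c3nc2-c2ccccc2)cc(OC)c1OC`, gives 37200 nM in this assay, and compound 3, `COc1ccc(CNc2nc3cc(N)cc(N)c3nc2-c2ccccc2)cc1`, gives 58900 nM. Going by the values given here, of these three numbers, the one for compound 1 is the highest, yet the gap to compound 3 and the gap to compound 2 both lie within the usual scatter of this assay, so the three are not separated by the data.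

Compound 4, `COc1ccc(Sc2nc3cc(N)cc(N)c3nc2-c2ccccc2)cc1`, has not yet been measured. It differs from compound 1 in one place: methoxy in place of fluoro on an aromatic carbon. Among the compounds with values here, no step between any two measured compounds is available to guide this change, so the expectation rests only on the three numbers already in hand. Compound 4 is expected to give 50000 nM in this assay, within a range from 20000 nM to 130000 nM. The expected step from compound 1 to compound 4 is thus a 1.3-fold lower number from compound 1 to compound 4 (0.11 log units; within the scatter), no larger than the scatter and in no firm direction.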

Compound 4, concentration lethal to 50% of the cells: < 100000 nM
Compound 4: a limit, no number; the forecaster's own chance of this, stated with the estimate: 10%; the middle value does not contradict the limit.
By their numbers in this assay, from the lowest: compounds 2, 3 and 1 (each within the scatter of the next).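

In this assay compound 4 gives < 100000 nM as a limit and not a number. Going by these compounds alone, no step from compound 1 to compound 4 can be read from it: the limit of < 100000 nM in this assay, at which 1 of the 4 values shown sits. As far as these compounds go, what methoxy in place of fluoro on an aromatic carbon does to the number in this test stays open.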